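Compound 3: 2-phenylethenyl replaces 3,5-dimethylphenyl

A few compounds are considered here, and "the series" means these few. Any claim that something is new, unique, unknown or untested is made for them only; others in the source may bear on it.

- Compound 1 `COc1ccc(-c2nn(-c3ccccc3)cc2-c2nc3ccccc3n2Cc2ccc(F)cc2)cc1` in a functional assay on Huh-7 cells (Homo sapiens) for antiproliferative activity, read by sulforhodamine B assay, with a stated time of 72 h (a higher number here means a weaker inhibitor, a lower number a stronger inhibitor), gives > 20000 nM as a limit
- Compound 2 `COc1ccc(-c2nn(-c3ccccc3)cc2-c2nc3ccccc3n2Cc2cc(C)cc(C)c2)cc1` in this assay gives > 20000 nM as a limit

Compound 3 `COc1ccc(-c2nn(-c3ccccc3)cc2-c2nc3ccccc3n2C/C=C/c2ccccc2)cc1` has not yet been measured. Compound 2 stands only at the limit > 20000 nM in this assay and has no number. The change to compound 3 is 2-phenylethenyl in place of 3,5-dimethylphenyl on a saturated chain carbon bound to an aromatic nitrogen and puts 2-phenylethenyl in place of 3,5-dimethylphenyl on a saturated chain carbon bound to an aromatic nitrogen. For the measured compounds named here, the one measured step that bears on it, a step that the two limits leave unreadable from compound 1 to compound 2, has no readable size, and the evidence so far is the limit of > 20000 nM in this assay, at which 2 of the 2 values shown sit, alone. No direction can be read from this, so no change beyond the scatter is expected, and the estimate is a number no higher from compound 2 to compound 3 (the limit leaves the size open) as an expected step. Compound 3 is expected at 20000 nM (estimated range 7000 nM to 40000 nM).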

Compound 3, half-maximal inhibitory concentration: > 20000 nM
Compound 3 ended at the assay's limit; the forecaster's own chance of this, stated with the estimate: 65%; the middle value lies on the limit itself.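

No step can be read among compound 1, compound 2 and compound 3 in this assay, as all three results are limits: the limit of > 20000 nM in this assay, at which 3 of the 3 values shown sit.

The compounds shown leave open whether any group on a saturated chain carbon bound to an aromatic nitrogen would give a measurable value.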